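Bromo on the fused ring of a paw edema series

The source may report more compounds than this note shows. Statements on the series, on what has been measured and on what is new or still open speak of the compounds shown alone.

For the measured compounds named here, compound 1 `COc1ccc(NCc2nc3ccccc3[nH]2)cc1` is one of three compounds measured in a functional assay on the whole organism (strain albino) for inhibition, with Rattus norvegicus as the target, read by paw edema, with a stated time of 60 min, at a dose of 100 mg/kg by the oral route (on this read-out lower numbers stand for less inhibition and higher numbers for more inhibition at the one dose given (going by the name of the read-out)), where compound 1 gives 26.6%. Compound 2 `c1ccc(NCc2nc3ccccc3[nH]2)cc1` gives 26.6% in this assay, and compound 3 `O=[N+]([O-])c1ccc2nc(CNc3ccc(Br)cc3)[nH]c2c1` gives 20%. On these numbers compound 1 stands level with compound 2, the two together at the high end of the three, while compound 3 reads somewhat lower, though that gap is within the scatter; no ordering among the three can be claimed.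

Going by the values given here, the one single-point step available, no change at the digits printed from compound 1 to compound 2 (within the scatter), removes the methoxy group on the aromatic carbon and leaves the read-out unmoved. Compound 4 `COc1ccc(NCc2nc3ccc(Br)cc3[nH]2)cc1` keeps the methoxy of compound 1 and instead carries the change (bromo in place of hydrogen on an aromatic carbon), on an aromatic carbon of the six-membered carbon-only ring that is part of the fused two-ring core. Among the compounds with values here, no measured step alters the core in this way; compound 3 carries substituents on both the core and the outer ring and still reads within the scatter of compound 1. The step of a number 1.6 percentage points lower from compound 1 to compound 4 (within the scatter) is therefore expected to be no larger than the scatter. Compound 4 is estimated at 25%, within 14% to 36%.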

Compound 4, a percentage reported as inhibition, in the whole organism at one dose (the size of the read-out at that dose, not a potency): 13.3%
Compound 4: middle estimate off by 11.7 percentage points, on the high side; the measured number lies below the stated range.
By their numbers in this assay, from the lowest: compounds 4, 3, 1 and 2 (each within the scatter of the next, the first and the last beyond it).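

In this assay, the aromatic carbon of the fused core is a place where a single-atom change registers: bromo in place of hydrogen gives a number 13.3 percentage points lower from compound 1 to compound 4 (beyond the scatter). For the compounds shown here, the only earlier step, no change at the digits printed from compound 1 to compound 2 (within the scatter), removed methoxy from the other ring and left the read-out unmoved, so the series now has one position that responds beyond the scatter and one that does not. This rests on one bromo compound at one oral dose, and nothing at hand gives a reason for the drop.

On these data alone, it remains open whether the drop belongs to bromo itself or to any group at this carbon; a fluoro, a methyl or a carboxylic acid there would separate the two. As far as these compounds go, it is also open whether bromo at this position gives a similar step when the other ring carries hydrogen instead of methoxy.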